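A few compounds are considered here, and "the series" means these few. Any claim that something is new, unique, unknown or untested is made for them only; others in the source may bear on it.

Working notes on the series. Compound 2 `CC(C)(C)CC(O)C(=O)Nc1sc2c(c1C(N)=O)CC(C)(C)OC2(C)C` carries an open-chain hydroxy-bearing amide on the shared core. In an assay on cells for positive allosteric modulation of Cystic fibrosis transmembrane conductance regulator variant G551D (Homo sapiens), with stated times of 10 min and 2 min, in the presence of a further agent that is not named here (on this read-out higher numbers stand for an effect only at larger amounts of compound and lower numbers for an effect already at smaller amounts), compound 2 gives 981 nM, the higher of the two numbers in hand. Its neighbour, compound 1 `CC1(C)Cc2c(sc(NC(=O)c3ccn[nH]3)c2C(N)=O)C(C)(C)O1`, with a five-membered aromatic ring on the carbonyl carbon, gives 339 nM in this assay. For the measured compounds named here, the single measured step, a 2.9-fold higher number from compound 1 to compound 2 (0.46 log units; beyond the scatter), is the replacement of that ring group by the open-chain group, a change that lies beyond the scatter.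

Compound 3 `Cc1cc(C(=O)Nc2sc3c(c2C(N)=O)CC(C)(C)OC3(C)C)[nH]n1` is the next member. The change from compound 2 is a group of 6 heavy atoms (4 carbon, 2 nitrogen; one five-membered aromatic ring with 2 hetero atoms) in place of a group of 7 heavy atoms (6 carbon, 1 oxygen; no ring), on a carbonyl carbon; what enters is 3-methyl-1H-pyrazol-5-yl, which leaves the open-chain group and returns a five-membered aromatic ring with two hetero atoms to the carbonyl carbon, the place whose other neighbour is an amide-type nitrogen. The step from compound 1 to compound 2 is the only one that bears on it, and it runs in the opposite direction. Since the step into compound 2 raised the number and the new ring resembles the ring of compound 1, a lower number for compound 3 is expected, with a step of about a 2.8-fold lower number from compound 2 to compound 3 (0.45 log units; beyond the scatter). The estimate for compound 3 in this assay is 350 nM, within a range from 150 nM to 800 nM.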

Compound 3, half-maximal effective concentration: 590 nM
Compound 3: middle estimate off by 1.7-fold (0.23 log units), on the low side; measured number inside the range.
By their numbers in this assay, from the lowest: compounds 1, 3 and 2 (each within the scatter of the next, the first and the last beyond it).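

In this assay the new comparison is methyl in place of hydrogen on an aromatic carbon, and the step of a 1.7-fold higher number from compound 1 to compound 3 (0.24 log units; within the scatter) shows that this change cannot be told apart from repeat measurement. The exchange of open-chain group for ring on the carbonyl carbon also reads differently now: the step of a 1.7-fold lower number from compound 2 to compound 3 (0.22 log units; within the scatter) lies within the scatter, whereas the step of a 2.9-fold higher number from compound 1 to compound 2 (0.46 log units; beyond the scatter) lay beyond it, so the separation from the open-chain group holds for the ring of compound 1 but is not shown for 3-methyl-1H-pyrazol-5-yl. No measurement in hand gives a reason for either step.

The compounds shown leave open whether a larger group on that aromatic carbon, such as ethyl, tert-butyl or trifluoromethyl, or an amine or a carboxylic acid there, would give a step beyond the scatter. They also leave open what the ring hydrogen on nitrogen and the hydroxy group of the open-chain amide contribute, which a ring carrying methyl on that nitrogen and the same chain without its hydroxy group could address.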